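The compounds below may be only part of what the source reports. "The series", "measured", "known", "first", "only" and "open" are said of these compounds alone.

Measured so far in a functional assay on CHO cells for agonist activity at Free fatty acid receptor 1 (Homo sapiens), read by FLIPR and calcium flux, in the presence of a further agent that is not named here; on this read-out lower numbers stand for an effect already at smaller amounts and higher numbers for an effect only at larger amounts of compound:
- compound 1 `Cc1cccc(-c2noc(COc3ccc(CCC(=O)O)cc3Cl)n2)c1` gives 4580 nM
- compound 2 `O=C(O)CCc1ccc(OCc2nc(-c3ccccc3Cl)no2)cc1` gives 1200 nM
- compound 3 `O=C(O)CCc1ccc(OCc2nc(-c3ccccc3)no2)cc1` gives 1130 nM

Compound 3 gives the lowest of the three numbers in this assay, but this does not set it apart from compound 2: a 1.1-fold lower number from compound 2 to compound 3 (0.03 log units; within the scatter), so the two cannot be ordered. Compound 1 stands furthest from compound 3; its value and that of compound 3 differ beyond the scatter, but compound 1 also differs from compound 3 in more than one place, so no single change can be read from that gap.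

The next compound is compound 4 `CC(Oc1ccc(CCC(=O)O)cc1)c1nc(-c2ccccc2)no1`. From compound 3 the change is methyl in place of hydrogen on a saturated chain carbon bound to an aromatic carbon and an oxygen on an aromatic ring. Among the compounds with values here, none of the measured steps touches this saturated chain carbon: the only single-change step in the set, a 1.1-fold lower number from compound 2 to compound 3 (0.03 log units; within the scatter), concerns a chloro group on an aromatic carbon and is itself within the scatter. The measured compounds therefore give no pointer in either direction for this change, and the step of a 1.0-fold lower number from compound 3 to compound 4 (0.01 log units; within the scatter) is expected to stay within the scatter or only a little beyond it. For compound 4 a value of 1100 nM is estimated, with a range of 400 nM to 3200 nM.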

Compound 4, half-maximal effective concentration: 2390 nM
The estimate for compound 4 lay 2.2-fold (0.34 log units) below the measured number; the range from low to high includes it.
By their numbers in this assay, from the lowest: compounds 3, 2, 4 and 1 (each within the scatter of the next, the first and the last beyond it).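

Methyl in place of hydrogen on a saturated chain carbon bound to an aromatic carbon and an oxygen on an aromatic ring gives a 2.1-fold higher number from compound 3 to compound 4 (0.33 log units; beyond the scatter) in this assay and is the first single change in the series to pass the scatter. The only earlier single-change step, a 1.1-fold lower number from compound 2 to compound 3 (0.03 log units; within the scatter) on an aromatic carbon, could not be read as a change, so this saturated chain carbon is the first place shown to be sensitive to substitution, with one added carbon moving the number upward by a modest amount. Nothing measured on hand accounts for this step.

Whether the step belongs to methyl in particular or would follow any group at this carbon stays open, as methyl is the only replacement for hydrogen shown there, and an ethyl group, a hydroxyl group or a fluoro group in the same place would begin to separate these cases. Also open, from the compounds shown here alone, is whether methyl gives a step of similar direction and size on the core of compound 2, which carries a chloro group on an aromatic carbon.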